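Dichlorobenzyl Ethers of a Diallyl Biphenol Tested on CNE2Z Cells

This account rests on a few compounds, and the source may have more. Where it says the series, first, only, none or still open, it means among the compounds named here.

Three ethers of a diallyl biphenol were measured in a functional assay on CNE2Z cells (Homo sapiens) for inhibition, read by MTT assay, with a stated time of 72 h; a lower number here means a stronger inhibitor, a higher number a weaker inhibitor. Compound 1 `C=CCc1ccc(OCc2ccc(Cl)cc2Cl)c(-c2ccc(O)c(CC=C)c2)c1` gives 24200 nM. Compound 3 `C=CCc1ccc(OCc2c(Cl)cccc2Cl)c(-c2ccc(O)c(CC=C)c2)c1` gives 19900 nM. Compound 2 `C=CCc1ccc(O)c(-c2ccc(OCc3c(Cl)cccc3Cl)c(CC=C)c2)c1` gives 16400 nM, and all three numbers sit within the scatter of one another, so no order among them can be claimed.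

Compound 1 is made from compound 3 by the change (2,4-dichlorophenyl in place of 2,6-dichlorophenyl on a saturated chain carbon bound to an oxygen on an aromatic ring), and the step in this assay is a 1.2-fold higher number from compound 3 to compound 1 (0.08 log units; within the scatter). Compound 4 `C=CCc1ccc(O)c(-c2ccc(OCc3ccc(Cl)cc3Cl)c(CC=C)c2)c1` is not yet measured. It arises from compound 2 by 2,4-dichlorophenyl in place of 2,6-dichlorophenyl on a saturated chain carbon bound to an oxygen on an aromatic ring, which is the same change on the same place; the difference between the core of compound 2 and the core of compound 3 is not broken down here.

Because the measured step of a 1.2-fold higher number from compound 3 to compound 1 (0.08 log units; within the scatter) stays within the scatter, the step from compound 2 to compound 4 in this assay is expected to be small as well, about a 1.2-fold higher number from compound 2 to compound 4 (0.06 log units; within the scatter). Compound 4 is therefore estimated at 19000 nM, with the expected range running from 9000 nM to 40000 nM.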

Compound 4, half-maximal inhibitory concentration: 11300 nM
Estimate against measurement, compound 4: 1.7-fold (0.23 log units) above, within the range that was stated.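

In this assay, 2,4-dichlorobenzyl in place of 2,6-dichlorobenzyl on the second core gives a 1.5-fold lower number from compound 2 to compound 4 (0.16 log units; within the scatter), a step too small to be read as a real change. Set beside the earlier step, the same change shows no difference between the two cores that this assay can resolve: the same change on two cores in this assay, a 1.2-fold higher number (0.08 log units; within the scatter) from compound 3 to compound 1 and a 1.5-fold lower number (0.16 log units; within the scatter) from compound 2 to compound 4, 1.8-fold (0.25 log units) apart, within the scatter of two such steps. This shows that, on these two cores, the change carries over without a detectable effect of the core; it does not show that the steps truly run in opposite directions, that the two dichlorobenzyl patterns are equivalent in general, or that the same would hold on any other core.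

The compounds shown all carry a dichlorobenzyl ether, a free hydroxyl and two allyl chains, so they cannot tell whether anything else would move the number beyond the scatter. Going by these compounds, it remains open what an unsubstituted benzyl group or an amine in place of the dichlorobenzyl group, a carboxylic acid in place of the hydroxyl, or a longer chain in place of an allyl chain would do.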